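Adding one methyl group to compound 3

The compounds below may be only part of what the source reports. "The series", "measured", "known", "first", "only" and "open" are said of these compounds alone.

Going by the values given here, in a functional assay on HSC-4 cells (Homo sapiens) for cytotoxicity, with a stated time of 24 h (on this read-out lower numbers stand for higher toxicity in this test and higher numbers for lower toxicity in this test), three compounds built on a shared core have numbers so far. Compound 1 `O=C1/C(=C/c2ccc(F)cc2)CCC/C1=C\c1ccccc1[N+](=O)[O-]` gives 2200 nM, compound 2 `COc1ccc(/C=C2\CCC/C(=C\c3ccccc3[N+](=O)[O-])C2=O)cc1` gives 24000 nM, and compound 3 `O=C1/C(=C/c2ccccc2)CCC/C1=C\c1cccc([N+](=O)[O-])c1` gives 2400 nM. Compound 3 thus lies within the usual scatter of compound 1, and its number is well under that of compound 2.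

The next structure, compound 4 `Cc1ccc(/C=C2\CCC/C(=C\c3cccc([N+](=O)[O-])c3)C2=O)cc1`, differs from compound 3 in one place: methyl in place of hydrogen on an aromatic carbon. Read one bond further out, the same change turns phenyl into 4-methylphenyl.

Among the compounds with values here, no measured step makes this exact exchange, so the evidence is only indirect. The closest guide is an 11-fold higher number from compound 1 to compound 2 (1.04 log units; beyond the scatter), where methoxy stands in place of fluoro on an aromatic carbon. That single step shows that one exchange on an aromatic carbon can move the number a long way here, but it involves different groups. It therefore widens the range more than it fixes the size of the step. The expected step is a 1.5-fold higher number from compound 3 to compound 4 (0.16 log units; within the scatter), a small one toward a higher number. Compound 4 is estimated at 3500 nM, with an expected range from 1200 nM to 11000 nM.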

Compound 4, half-maximal cytotoxic concentration: 45000 nM
For compound 4 the middle estimate is 13-fold (1.11 log units) below the measured one; measured number above the stated range.
By their numbers in this assay, from the lowest: compounds 1 and 3 (each within the scatter of the next); then compounds 2 and 4 (each within the scatter of the next).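

In this assay, putting methyl in place of hydrogen on this aromatic carbon, para to a large group, gives a 19-fold higher number from compound 3 to compound 4 (1.27 log units; beyond the scatter). Going by these compounds alone, the only earlier step, an 11-fold higher number from compound 1 to compound 2 (1.04 log units; beyond the scatter), swapped one substituent for another, so it could not show what happens when a group is added to an unsubstituted carbon; this step shows that, on the core of compound 3, a group of just 1 carbon with no hydrogen-bond donors or acceptors is enough for a large move toward lower toxicity in this test. Nothing measured here accounts for so large a step from so small an addition.

The compounds shown leave open whether this step is particular to methyl or would also appear with a longer chain such as ethyl, or with an amine or a carboxylic acid on the same carbon. They also leave open whether the same methyl would produce a step of similar size with the nitro group placed as it is in compound 1.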